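The source may report more compounds than this note shows. Statements on the series, on what has been measured and on what is new or still open speak of the compounds shown alone.

Compound 1 `CCOc1nc(-c2nc3ccccc3n2C)cc(-c2ccccc2)c1C#N`: in a functional assay on aorta (Rattus norvegicus, strain Wister) (a higher number here means a weaker inhibitor, a lower number a stronger inhibitor), compound 1 gives 364000 nM.
Compound 2 `CCOc1nc(-c2nc3ccccc3n2C)cc(-c2ccc(Cl)cc2Cl)c1C#N`: in this assay compound 2 gives 305000 nM.
Compound 3 `COc1nc(-c2nc3ccccc3n2C)cc(-c2ccc(F)cc2)c1C#N`: in this assay compound 3 gives 343000 nM.

The three measured compounds share one core and differ only in the aryl group attached to it. Compound 3 stands second highest of the three numbers, but its gaps to compound 1 and to compound 2 are both within the scatter, so the three values cannot be told apart. Within the data shown here, the only single-point step among them, a 1.2-fold lower number from compound 1 to compound 2 (0.08 log units; within the scatter), shows that exchanging one aryl group for another left the number where it was.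

Compound 4 `COc1nc(-c2nc3ccccc3n2C)cc(-c2ccc(C)o2)c1C#N` carries the change (5-methylfuran-2-yl in place of 4-fluorophenyl on an aromatic carbon). Among the measured compounds shown here, no measured step covers a swap of a six-membered carbon ring for a five-membered ring with one hetero atom, so the step from compound 1 to compound 2 is the only guide, and it was within the scatter. On that basis no step beyond the scatter is expected in this assay from compound 3 to compound 4, in either direction.

Compound 4 is therefore expected to give about 340000 nM in this assay, somewhere between 150000 nM and 750000 nM. The expected step of a 1.0-fold lower number from compound 3 to compound 4 (0.00 log units; within the scatter) is essentially none.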

Compound 4, half-maximal inhibitory concentration: 283000 nM
Compound 4: middle estimate off by 1.2-fold (0.08 log units), on the high side; the range from low to high includes it.
By their numbers in this assay, from the lowest: compounds 4, 2, 3 and 1 (each within the scatter of the next).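

The change from 4-fluorophenyl to 5-methylfuran-2-yl, on the aromatic carbon opposite the ring nitrogen, gives a 1.2-fold lower number from compound 3 to compound 4 (0.08 log units; within the scatter) in this assay. The earlier step covered only a change of substituents on a six-membered aromatic ring of carbon only, whereas this one replaces that ring with a five-membered aromatic ring with one hetero atom, adds a hydrogen-bond acceptor, and still leaves the number within the scatter, with compound 4 at 283000 nM. No measurement shown here offers an explanation for this lack of movement.

As far as these compounds go, whether an aminomethyl group, a carboxylic acid or a saturated ring such as piperidine at this position would move the number beyond the scatter remains open. Also open are the effect of methoxy against ethoxy, for which no pair among the compounds shown differs in that place alone, and the effect of replacing the nitrile with a carboxamide.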